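Shrinking the carbamate ester: compound 2 to compound 3

This account rests on a few compounds, and the source may have more. Where it says the series, first, only, none or still open, it means among the compounds named here.

Measured so far:
compound 1 `Cc1cc(C(N)=O)nn1Cc1cc(Cl)ccc1OCc1ccccc1` — 126 nM
compound 2 `Cc1cc(NC(=O)OC(C)(C)C)nn1Cc1cc(Cl)ccc1OCc1ccccc1` — 25.1 nM

In an assay on CHO-K1 cells for displacement of a labelled ligand from prostaglandin E2 receptor EP1 subtype (Homo sapiens) (a higher number here means a weaker inhibitor, a lower number a stronger inhibitor), compound 2 gives 25.1 nM, the lowest of the two numbers, and compound 1 gives 126 nM. Among the measured compounds shown here, the one measured step, a 5.0-fold lower number from compound 1 to compound 2 (0.70 log units; beyond the scatter), concerns the group on the aromatic carbon, not the ester end of the carbamate. Compound 3 `COC(=O)Nc1cc(C)n(Cc2cc(Cl)ccc2OCc2ccccc2)n1` differs from compound 2 by methyl in place of tert-butyl on an oxygen next to a carbonyl group. For the measured compounds named here, no measured step bears on this change, so only a small move from compound 2 is expected, a 2.0-fold higher number from compound 2 to compound 3 (0.30 log units; within the scatter), toward a somewhat higher number. The estimate for compound 3 in this assay is 50 nM, range 15 nM to 170 nM.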

Compound 3, half-maximal inhibitory concentration: 200 nM
Estimate against measurement, compound 3: 4.0-fold (0.60 log units) below; measured number above the stated range.
By their numbers in this assay, from the lowest: compound 2; then compounds 1 and 3 (each within the scatter of the next).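

In this assay the ester end of the carbamate matters: methyl in place of tert-butyl gives an 8.0-fold higher number from compound 2 to compound 3 (0.90 log units; beyond the scatter), so the (methoxycarbonyl)amino group does not keep the advantage of compound 2. Against carbamoyl, that group shows a 1.6-fold higher number from compound 1 to compound 3 (0.20 log units; within the scatter), which places the advantage of compound 2 with the tert-butyl end and not with the carbamate linkage alone. No measurement here accounts for the loss.

On these data alone, what ethyl or isopropyl on that oxygen would give remains open. So does how an amine or a urea on the aromatic carbon would compare.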